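Chloro for methoxy on the aryl group of compound 2

This account rests on a few compounds, and the source may have more. Where it says the series, first, only, none or still open, it means among the compounds named here.

Within the data shown here, in a functional assay on the whole organism (Hindlimb, strain albino) with Mus musculus as the target, in the maximal electroshock model, with a stated time of 0.5 h (on this read-out lower numbers stand for an effect already at smaller amounts and higher numbers for an effect only at larger amounts of compound), compound 2 (`COc1ccc(C2CC(Nc3nc4ccc(Cl)cc4s3)=NN2C(C)=O)cc1`) gives 93.3 umol/kg as the lower of the two numbers so far, while compound 1 (`CC(=O)N1N=C(Nc2nc3ccccc3s2)CC1c1ccc(Cl)cc1`) gives 209 umol/kg as the higher, a gap beyond the scatter. Compound 3 (`CC(=O)N1N=C(Nc2nc3ccc(Cl)cc3s2)CC1c1ccc(Cl)cc1`) differs from compound 2 by chloro in place of methoxy on an aromatic carbon in the change of 4-methoxyphenyl to 4-chlorophenyl. Among the measured compounds shown here, no measured pair isolates this change, so the data offer no direct guide to it. In this assay the expected 1.1-fold higher number from compound 2 to compound 3 (0.05 log units; within the scatter) stays within the scatter. Compound 3 is expected at 105 umol/kg with 48 umol/kg to 230 umol/kg as the estimated range.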

Compound 3, dose for half-maximal effect: 79.5 umol/kg
Compound 3: the middle estimate sits 1.3-fold (0.12 log units) above what was measured; measured number inside the range.
By their numbers in this assay, from the lowest: compounds 3 and 2 (each within the scatter of the next); then compound 1.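

At the para position of the aryl group, swapping methoxy for chloro with the chloro already on the core leaves the read-out in this assay essentially unmoved (a 1.2-fold lower number from compound 2 to compound 3 (0.07 log units; within the scatter)), so this position tolerates either group here. Chloro in place of hydrogen on an aromatic carbon of the core is the step that registers (a 2.6-fold lower number from compound 1 to compound 3 (0.42 log units; beyond the scatter)), although this single pair is modest support. No available evidence accounts for either step.

As far as these compounds go, whether an amine, a carboxylic acid or a longer alkoxy chain at the aryl position would keep the number in this range remains open. Also open, from the compounds shown here alone, is whether the hydrogen-to-chloro step on the core would carry over with 4-methoxyphenyl in place of 4-chlorophenyl.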